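The compounds below may be only part of what the source reports. "The series", "measured", "known", "first", "only" and "open" are said of these compounds alone.

In a toxicity assay on CHO cells (Cricetulus griseus) for cytotoxicity, read by WST assay, with a stated time of 24 h (on this read-out lower numbers stand for stronger inhibition and higher numbers for weaker inhibition), compound 1 (`CC(C)=CCCC(C)=CCNCCCN(CCCN)CCCN`) gives 127000 nM while compound 2 (`CC(C)=CCC/C(C)=C\CCC(C)=CCNCCCCN`) gives 18100 nM and compound 3 (`CC(C)=CCC/C(C)=C\CCC(C)=CCNCCCN1CCN(CCCN)CC1`) comes in at 33800 nM on the same scale. Compound 2 therefore sits at the low end of this small set, on the side of stronger inhibition. Its number and that of compound 3 lie within the usual scatter of each other, whereas compound 1 lies beyond the scatter from compound 2, on the side of weaker inhibition.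

The next compound to consider is compound 4 (`CC(C)=CCC/C(C)=C\CCC(C)=CCNCCCN(C)CCCN`). It keeps the rest of compound 2 but carries (3-aminopropyl)(methyl)amino in place of aminomethyl on a saturated chain carbon, three bonds along the chain from an amine nitrogen.

For the measured compounds named here, no two measured compounds differ in only one place, so no measured step speaks directly to this change. The nearest guide is compound 3, which also has a longer amine chain than compound 2, and compound 3 still gives 33800 nM as its number. On that basis, the expected step of a 1.4-fold higher number from compound 2 to compound 4 (0.16 log units; within the scatter) is a small one toward a higher number, not beyond the scatter. In this assay compound 4 is estimated at 26000 nM (expected range 12000 nM to 55000 nM).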

Compound 4, half-maximal inhibitory concentration: 10500 nM
For compound 4 the middle estimate is 2.5-fold (0.39 log units) above the measured one; the whole stated range lies above it.
By their numbers in this assay, from the lowest: compounds 4, 2 and 3 (each within the scatter of the next, the first and the last beyond it); then compound 1.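

For the compounds shown here, this is the first pair in the set that differs in only one place, so the effect of this change can now be read directly. In this assay, replacing aminomethyl with (3-aminopropyl)(methyl)amino on a saturated chain carbon, three bonds along the chain from an amine nitrogen, gives a 1.7-fold lower number from compound 2 to compound 4 (0.24 log units; within the scatter), so the read-out does not separate the two compounds even though the entering group has 6 heavy atoms and the leaving group has 2. Nothing measured alongside this result explains why the two numbers stay so close.

From the compounds shown here alone, it remains open how the read-out would respond if a carboxylic acid or a hydroxyl group stood at the same place, or if an ethyl group took the place of the methyl in (3-aminopropyl)(methyl)amino. Going by these compounds, whether this exchange would behave the same way on a different core, such as that of compound 1, also stays open, since this single step speaks only for the core of compound 2.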